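Fluoro Added Beside a Trifluoromethyl on the Urea Aryl

The compounds below may be only part of what the source reports. "The series", "measured", "known", "first", "only" and "open" are said of these compounds alone.

Measured compounds:
Compound 1 `O=C(Nc1ccccc1)Nc1ccc(Oc2ccc(-c3nccs3)cc2)cc1`: "not determined" (no result reported)
Compound 2 `O=C(Nc1ccc(Oc2ccc(-c3nccs3)cc2)cc1)Nc1cccc(C(F)(F)F)c1`: 71.5%

Two compounds share the same diaryl ether urea core. Within the data shown here, for compound 1 the entry in a functional assay on A549 cells (Homo sapiens) for inhibition, read by MTT assay and WST assay, with a stated time of 72 h, tested at 10 uM (a lower number here means less inhibition of growth, a higher number more inhibition of growth at the concentration tested), reads "not determined" (no result reported), so compound 2 carries the only value available. In this assay compound 2 gives 71.5%, and with no second number there is nothing to rank it against; it simply stands alone as the single reference point.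

Compound 3 `O=C(Nc1ccc(Oc2ccc(-c3nccs3)cc2)cc1)Nc1ccc(F)c(C(F)(F)F)c1` differs from compound 2 in one place: fluoro in place of hydrogen on an aromatic carbon. Among the measured compounds shown here, there is no measured pair showing what such an exchange does, so the expected size of the step cannot be anchored to any earlier observation. With one heavy atom entering and the rest of the structure unchanged, the change from compound 2 to compound 3 is expected to stay close to the scatter of this assay, with no clear direction, and it is estimated at a number 0.5 percentage points higher from compound 2 to compound 3 (within the scatter).

Compound 3 is therefore expected to give about 72% in this assay, within a range of 55% to 88%.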

Compound 3, percent growth inhibition at one concentration: 76.4%
Estimate against measurement, compound 3: 4.4 percentage points below; the measured number falls inside the stated range.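

In this assay, placing a fluoro on an aromatic carbon ortho to a trifluoromethyl group and para to a large group gives a number 4.9 percentage points higher from compound 2 to compound 3 (within the scatter), so the two compounds cannot be told apart by this read-out. Among these compounds, this is the first measured pair, and it shows that the 3-(trifluoromethyl)phenyl can become 4-fluoro-3-(trifluoromethyl)phenyl with growth inhibition at the tested concentration staying within the usual scatter, which no single earlier value could show. No evidence on the reason for this result is at hand.

The compounds shown leave open whether this position would respond in the same way to a chlorine, a methoxy group, an amine or a carboxylic acid, since a single fluoro exchange on one compound says nothing about those groups or about the same fluoro on another aryl. They also leave open how the plain phenyl urea compares with either trifluoromethyl compound, as the entry for compound 1 reads "not determined" (no result reported) and gives nothing to set against them.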